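Aryl piperazine ketones: cytotoxicity notes on a small series

The compounds below may be only part of what the source reports. "The series", "measured", "known", "first", "only" and "open" are said of these compounds alone.

Measured so far:
compound 1, `O=C(CCN1CCN(c2ccc(Cl)cc2)CC1)c1ccc(F)c(F)c1`, 86200 nM
compound 2, `O=C(CCN1CCN(c2ccc([N+](=O)[O-])cc2)CC1)c1ccc(F)c(F)c1`, 122000 nM
compound 3, `O=C(CCN1CCN(c2ccc(Cl)cc2)CC1)c1ccc(Cl)c(F)c1`, 175000 nM

All three were tested in an ADME assay on Vero cells (Chlorocebus sabaeus) for cytotoxicity, read by resazurin assay, with a stated time of 72 h; on this read-out lower numbers stand for stronger inhibition and higher numbers for weaker inhibition. From compound 1 to compound 2 the change is nitro in place of chloro on an aromatic carbon, and this gave a 1.4-fold higher number from compound 1 to compound 2 (0.15 log units; within the scatter). Compound 3 carries a different core, the difference being (chloro in place of fluoro on an aromatic carbon), and this gave a 2.0-fold higher number from compound 1 to compound 3 (0.31 log units; beyond the scatter). Compound 4, `O=C(CCN1CCN(c2ccc([N+](=O)[O-])cc2)CC1)c1ccc(Cl)c(F)c1`, has not yet been measured in this assay. It differs from compound 3 by nitro in place of chloro on an aromatic carbon, the same change already seen from compound 1 to compound 2, here made on the core of compound 3. For compound 4 a step of a 1.3-fold higher number from compound 3 to compound 4 (0.10 log units; within the scatter) is expected, resting on the earlier step of a 1.4-fold higher number from compound 1 to compound 2 (0.15 log units; within the scatter). The value expected for compound 4 is 220000 nM. For compound 4 the estimated range runs from 110000 nM to 450000 nM.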

Compound 4, half-maximal inhibitory concentration: 89200 nM
Beside the measured number, compound 4's estimate is 2.5-fold (0.39 log units) above it; measured number outside the range, below it.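

In this assay, the change from 4-chlorophenyl to 4-nitrophenyl does not carry over as a fixed step from the core of compound 1 to the core of compound 3, the new step being a 2.0-fold lower number from compound 3 to compound 4 (0.29 log units; within the scatter), and the two steps differ: the same change on two cores in this assay, a 1.4-fold higher number (0.15 log units; within the scatter) from compound 1 to compound 2 and a 2.0-fold lower number (0.29 log units; within the scatter) from compound 3 to compound 4, 2.8-fold (0.44 log units) apart, beyond the scatter of two such steps

The change of chloro in place of fluoro on an aromatic carbon gives the same picture, the new step being a 1.4-fold lower number from compound 2 to compound 4 (0.14 log units; within the scatter), and again the two steps differ: the same change on two cores in this assay, a 2.0-fold higher number (0.31 log units; beyond the scatter) from compound 1 to compound 3 and a 1.4-fold lower number (0.14 log units; within the scatter) from compound 2 to compound 4, 2.8-fold (0.44 log units) apart, beyond the scatter of two such steps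

Both gaps come from the same four compounds and so count as one observation, which shows that the steps do not simply add but gives no reason for this and establishes no true reversal of direction, the new steps themselves lying within the scatter.

Going by these compounds, whether the same gap appears with an amine or a carboxylic acid in place of the nitro group remains open. So does the effect of a longer chain in the shared core.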